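The compounds below may be only part of what the source reports. "The series", "measured", "known", "first", "only" and "open" are said of these compounds alone.

In a physicochemical assay for lipophilicity (a higher number here means a more lipophilic compound, a lower number a more polar compound), compound 1 `COc1c(OC)c(OC(C)=O)c2cc(F)ccc2c1OC(C)=O` gives 2.75, compound 2 `COc1c(OC)c(OC(C)=O)c2cc(Br)ccc2c1OC(C)=O` gives 3.39 and compound 3 `CCCOc1c(OCCC)c(OC(=O)C(C)(C)C)c2cc(Cl)ccc2c1OC(=O)C(C)(C)C` gives 8.5. Compound 2 is thus the second highest of the three, much nearer compound 1 than compound 3. Compound 4 `COc1c(OC)c(OC(C)=O)c2cc(C)ccc2c1OC(C)=O` differs from compound 2 as follows: methyl in place of bromo on an aromatic carbon. Among the measured compounds shown here, only one measured step bears on this change: a number 0.64 log units higher from compound 1 to compound 2 (beyond the scatter), a modest rise with bromo in place of fluoro on an aromatic carbon. For the measured compounds named here, compound 3 differs in several places and offers no comparable step. With methyl in place of bromo, a small fall in this assay is expected, smaller than that measured step and perhaps within the scatter. The expected change is a number 0.24 log units lower from compound 2 to compound 4 (within the scatter). For compound 4 the estimated value is 3.15, with an expected range of 2.75 to 3.5.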

Compound 4, partition coefficient: 2.86
For compound 4 the middle estimate is 0.29 log units above the measured one, and the stated range covers the measured number.
By their numbers in this assay, from the lowest: compounds 1 and 4 (each within the scatter of the next); then compound 2; then compound 3.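

In this assay, methyl in place of bromo at this position gives a number 0.53 log units lower from compound 2 to compound 4 (beyond the scatter), so this change moves the number beyond the scatter. Methyl in place of fluoro gives a number 0.11 log units higher from compound 1 to compound 4 (within the scatter), so among these three groups on the shared core, only bromo stands apart from the other two. No measured evidence here accounts for this difference. From the compounds shown here alone, it remains open where an amine or a carboxylic acid at this position would fall relative to these groups. Going by these compounds, it is equally open whether a longer chain in place of methyl would stay level with fluoro.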